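Swapping the aromatic group on a shared core

A few compounds are considered here, and "the series" means these few. Any claim that something is new, unique, unknown or untested is made for them only; others in the source may bear on it.

Measured in a functional assay on KB cells (Homo sapiens) for inhibition, with a stated time of 72 h; a higher number here means a weaker inhibitor, a lower number a stronger inhibitor:
- compound 1 `COc1ccc(S(=O)(=O)N2CCc3cccc(-c4ccc(F)nc4)c32)cc1`: 143 nM
- compound 2 `COc1ccc(S(=O)(=O)N2CCc3cccc(-c4ccc(F)cc4)c32)cc1`: 86 nM
- compound 3 `COc1ccc(S(=O)(=O)N2CCc3cccc(-c4ccc(O)cc4)c32)cc1`: 129 nM

The three compounds share one core and differ only in the aromatic group it carries. At 129 nM, compound 3 sits within the scatter of both other compounds, so the three numbers cannot be ranked. Its measured neighbours show this in two steps: a 1.1-fold lower number from compound 1 to compound 3 (0.04 log units; within the scatter), and a 1.5-fold higher number from compound 2 to compound 3 (0.18 log units; within the scatter).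

Compound 4 `COc1ccc(S(=O)(=O)N2CCc3cccc(-c4cccs4)c32)cc1` is still unmeasured. It carries thiophen-2-yl in place of 4-hydroxyphenyl on an aromatic carbon. Going by the values given here, no measured compound has a five-membered aromatic ring at this place, so no step bears on that change directly. The nearest evidence is the other exchanges of the whole group, which also stayed small: a 1.7-fold lower number from compound 1 to compound 2 (0.22 log units; within the scatter), alongside a 1.1-fold lower number from compound 1 to compound 3 (0.04 log units; within the scatter). Exchanges of this kind have so far left this assay essentially unmoved, so no change beyond the scatter is expected, though the new ring type widens the uncertainty. The estimated step is a 1.2-fold lower number from compound 3 to compound 4 (0.07 log units; within the scatter). For compound 4 the expected value is 110 nM, with an estimated range from 50 nM to 250 nM.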

Compound 4, half-maximal inhibitory concentration: 215 nM
Beside the measured number, compound 4's estimate is 2.0-fold (0.29 log units) below it; low and high end bracket the measured number.
By their numbers in this assay, from the lowest: compounds 2, 3, 1 and 4 (each within the scatter of the next, the first and the last beyond it).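

In this assay, going by these compounds alone, the exchange of the whole aromatic group at this place now produces a step that clears the scatter for the first time: a 2.5-fold higher number from compound 2 to compound 4 (0.40 log units; beyond the scatter). The place is therefore not wholly indifferent to the group it carries, but the evidence is a single pair, since with a 1.7-fold higher number from compound 3 to compound 4 (0.22 log units; within the scatter) and with a 1.5-fold higher number from compound 1 to compound 4 (0.18 log units; within the scatter) the same ring exchange stays within the scatter, and thiophen-2-yl cannot be ranked against 4-hydroxyphenyl or 6-fluoropyridin-3-yl. No other measurement bears on why the number differs between these compounds.

The compounds shown leave open whether this gap belongs to five-membered aromatic rings in general or to thiophen-2-yl alone, which furan-2-yl or thiophen-3-yl at the same place would help to separate. They also leave open how far the number would move with a group that has no aromatic ring at all, such as a morpholine, or with a phenyl ring bearing an amine or a carboxylic acid.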